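Swapping Nitro for Chloro: An Expected Lipophilicity Shift

This account rests on a few compounds, and the source may have more. Where it says the series, first, only, none or still open, it means among the compounds named here.

Measured so far:
compound 1, `Cc1ccc(Oc2ccc(/C=N/NC(=O)CSc3nc4ccccc4s3)cc2)cc1`: 5.7
compound 2, `O=[N+]([O-])c1ccc(Oc2ccc(/C=N/Nc3nc4ccccc4s3)cc2)cc1`: 5.1

Among the compounds with values here, both compounds have been measured in a physicochemical assay for lipophilicity, in phosphate buffer, measured as octanol-water partition, with a stated time of 24 h; a lower number here means a more polar compound, a higher number a more lipophilic compound. Of the two numbers, compound 2 gives the lower one; compound 1 stands higher by a gap that is beyond the scatter of the method. The two compounds differ in several places at once, so no single change can be read from that gap.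

Compound 3, `Clc1ccc(Oc2ccc(/C=N/Nc3nc4ccccc4s3)cc2)cc1`, has not yet been measured in this assay. It differs from compound 2 in one place: chloro in place of nitro on an aromatic carbon. Within the data shown here, no measured pair of compounds shows this particular change, so nothing in the data fixes its size. Still, a step upward, beyond the scatter, is expected from compound 2 to compound 3, a number 1.00 log units higher from compound 2 to compound 3 (beyond the scatter). For compound 3 the estimated result is 6.1, with a likely range from 5.6 to 6.6.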

Compound 3, partition coefficient: 5.6
Beside the measured number, compound 3's estimate is 0.50 log units above it, within the range that was stated.
By their numbers in this assay, from the lowest: compound 2; then compounds 3 and 1 (each within the scatter of the next).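

In this assay the exchange of 4-nitrophenyl for 4-chlorophenyl gives a number 0.50 log units higher from compound 2 to compound 3 (beyond the scatter) and so puts a first measured size on this change at this position. Compound 2 and compound 3 differ in one place only, which makes this the first gap in the set that can be tied to a single change: chloro in place of nitro on an aromatic carbon, para to a large group. Nothing measured here accounts for the size of the step, so it stands as an observation without an explanation.

The compounds shown leave open how an amine or a carboxylic acid on the same aromatic carbon would read in this measurement. They also leave open whether the same exchange of nitro for chloro would give a step of similar size on a different core.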